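The source may report more compounds than this note shows. Statements on the series, on what has been measured and on what is new or still open speak of the compounds shown alone.

Measured compounds:
compound 1 `CC(C)Oc1ccccc1N1CCN(CCN(C)C(=O)CN2CCCCC2=O)CC1`, 10000 nM;
compound 2 `COc1ccccc1N1CCN(CCCNC(=O)CN2CCCCC2=O)CC1`, 10000 nM;
compound 3 `CC(C)Oc1cc(F)ccc1N1CCN(CCNC(=O)CN2CCCCC2=O)CC1`, 10000 nM.

In an assay on COS cells for binding affinity to Alpha-1B adrenergic receptor (Homo sapiens) (on this read-out lower numbers stand for stronger inhibition and higher numbers for weaker inhibition), compound 3 gives 10000 nM, level with compound 1 and compound 2 at the digits recorded; the nearest is compound 1, the furthest compound 2, both within the scatter. Within the data shown here, no pair of measured compounds differs in a single place, so the weight of any one change in this assay is unknown from these three. Compound 4 `O=C(CN1CCCCC1=O)NCCN1CCN(c2ccc(F)cc2OCC(F)(F)F)CC1` is to be measured in this assay. From compound 3 to compound 4 the change is 2,2,2-trifluoroethyl in place of isopropyl on an oxygen on an aromatic ring. All three measured values sit at the same level, so no step beyond the scatter is expected. The expected step is no change at the digits printed from compound 3 to compound 4 (within the scatter). For compound 4 the estimate in this assay is 10000 nM, range 4000 nM to 10000 nM.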

Compound 4, inhibition constant: 10000 nM
Beside the measured number, compound 4's estimate shows no gap at the digits printed; the range from low to high includes it.
By their numbers in this assay, from the lowest: compounds 1, 2, 3 and 4 (each within the scatter of the next).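

In this assay, among these compounds, 2,2,2-trifluoroethyl in place of isopropyl on an oxygen on an aromatic ring gives no change at the digits printed from compound 3 to compound 4 (within the scatter) and is the only single-place step so far. At this position, going from isopropoxy to 2,2,2-trifluoroethoxy therefore does not separate the two compounds on this read-out. Nothing at hand gives a reason for this result.

On these data alone, whether a longer chain, an amine or a carboxylic acid on that oxygen would shift the value stays open. The steps among the other compounds cannot be read, as those pairs differ in more than one place.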